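A few compounds are considered here, and "the series" means these few. Any claim that something is new, unique, unknown or untested is made for them only; others in the source may bear on it.

Measured so far:
compound 1, `Cc1cc(C)cc(S(=O)(=O)c2c(C(=O)NCC(=O)NC(C)c3ccccc3)[nH]c3ccc(Cl)cc23)c1`: 29400 nM
compound 2, `COc1cccc(F)c1CNC(=O)c1[nH]c2ccc(Cl)cc2c1S(=O)(=O)c1cc(C)cc(C)c1`: a limit, > 49900 nM
compound 3, `Cc1cc(C)cc(S(=O)(=O)c2c(C(=O)NC(C)C(=O)NC(C)c3ccccc3)[nH]c3ccc(Cl)cc23)c1`: 21700 nM

In an ADME assay on MT4 cells (Homo sapiens) for cytotoxicity, read by MTT assay (on this read-out lower numbers stand for higher toxicity in this test and higher numbers for lower toxicity in this test), compound 1 stands highest of the two numbers shown; the step of a 1.4-fold lower number from compound 1 to compound 3 (0.13 log units; within the scatter) is the nearest and stays within the scatter. Compound 2 gives only a limit. Compound 4 `Cc1cc(C)cc(S(=O)(=O)c2c(C(=O)NC(C)c3cc(F)cc(F)c3)[nH]c3ccc(Cl)cc23)c1` differs from compound 1 by 1-(3,5-difluorophenyl)ethyl in place of ((1-phenylethyl)carbamoyl)methyl on an amide-type nitrogen. Within the data shown here, no measured step makes the same change. The closest is an at least 1.6-fold higher number from compound 1 to compound 2 (0.22 log units; that floor lies within the scatter), which also removed the (1-phenylethyl)carbamoyl part and ended at the limit of > 49900 nM in this assay, at which 1 of the 3 values shown sits, while a 1.4-fold lower number from compound 1 to compound 3 (0.13 log units; within the scatter) touched only a saturated chain carbon. Neither points to a shift beyond the scatter, so compound 4 is expected to sit near compound 1, with an expected step of a 1.2-fold higher number from compound 1 to compound 4 (0.08 log units; within the scatter). The estimate for compound 4 is 35000 nM, between 15000 nM and 60000 nM.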

Compound 4, half-maximal cytotoxic concentration: > 49700 nM
Compound 4: no number, only a limit; the forecaster's own chance of this, stated with the estimate: 35%; at least 1.4-fold (0.15 log units) between middle value and limit.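

In this assay compound 4 gives only a limit: the limit of > 49700 nM in this assay, at which 1 of the 4 values shown sits.

The exchange on the amide-type nitrogen gives an at least 1.6-fold higher number from compound 1 to compound 4 (0.22 log units; that floor lies within the scatter), while an at least 2.2-fold higher number from compound 3 to compound 4 (0.35 log units; beyond the scatter) is the first step shown that passes beyond the scatter. The compounds lacking the (1-phenylethyl)carbamoyl part, compound 2 and compound 4, both end at limits, so the step between them cannot be read.

Going by these compounds, how far compound 4 lies past its limit stays open. So does whether a plain 1-phenylethyl on the amide-type nitrogen, without the two fluorines, would read the same.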